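A few compounds are considered here, and "the series" means these few. Any claim that something is new, unique, unknown or untested is made for them only; others in the source may bear on it.

Among the measured compounds shown here, in a functional assay on RBL-2H3 cells (Rattus norvegicus) for inhibition, with stated times of 30 min and 1 h (on this read-out higher numbers stand for weaker inhibition and lower numbers for stronger inhibition), compound 2 `COc1ccc(CN(CCN(C)C)c2ccc(N)cn2)cc1` gives 2110 nM, the higher of the two numbers so far, while compound 1 `COc1ccc(CN(CCN(C)C)c2ccc(C)cc2)cc1` gives 89.1 nM. Compound 3 `COc1ccc(CN(CCN(C)C)c2ccc(C)cn2)cc1` differs from compound 2 by a single change, methyl in place of amino on an aromatic carbon. For the measured compounds named here, the only measured step that bears on it is a 24-fold higher number from compound 1 to compound 2 (1.37 log units; beyond the scatter), a large step in which 5-aminopyridin-2-yl replaces 4-methylphenyl on an amine nitrogen. That step alters the ring and its substituent together, and the data do not separate the two. Compound 3 pairs the ring nitrogen of compound 2 with a methyl, as in compound 1, so part of that large step is expected to be recovered, giving a clear move to a lower number: a 7.0-fold lower number from compound 2 to compound 3 (0.85 log units; beyond the scatter). For compound 3 the estimated value in this assay is 300 nM, with an expected range of 80 nM to 1100 nM.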

Compound 3, half-maximal inhibitory concentration: 48.6 nM
The estimate for compound 3 lay 6.2-fold (0.79 log units) above the measured number; the measured number lies below the stated range.
By their numbers in this assay, from the lowest: compounds 3 and 1 (each within the scatter of the next); then compound 2.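

In this assay, exchanging amino for methyl on this aromatic carbon, two atoms from the ring nitrogen and para to a large group, gives a 43-fold lower number from compound 2 to compound 3 (1.64 log units; beyond the scatter). With methyl held in place, the ring exchange gives a 1.8-fold lower number from compound 1 to compound 3 (0.26 log units; within the scatter), within the scatter, so the large step of a 24-fold higher number from compound 1 to compound 2 (1.37 log units; beyond the scatter) is matched by the amino-to-methyl change, and the ring nitrogen alone shows no change on this read-out. No measurement given here explains why these two groups differ so widely.

The compounds shown carry only amino and methyl at this place, so how a hydroxyl, a methoxy or an ethyl group would read there remains open. Also open, as far as these compounds go, is whether amino on the phenyl ring of compound 1 would give a step of similar size.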